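This account rests on a few compounds, and the source may have more. Where it says the series, first, only, none or still open, it means among the compounds named here.

Measured so far:
- compound 1 `CCNC(=O)Nc1sc2ccccc2c1C(=O)N1CCN(C2CCN(C(=O)OC(C)C)CC2)CC1`: 208 nM
- compound 2 `CCNC(=O)Nc1sc2ccccc2c1C(=O)N1CCN(C2CCN(C(=O)OC3CCCCC3)CC2)CC1`: 635 nM

Both values come from a functional assay on HepG2 cells (Homo sapiens) for inhibition, read by scintillation counting, with a stated time of 2 h; a higher number here means a weaker inhibitor, a lower number a stronger inhibitor. Of the two, compound 2 has the higher number and so is the weaker inhibitor. Going by the values given here, the one measured step, a 3.1-fold higher number from compound 1 to compound 2 (0.48 log units; beyond the scatter), put cyclohexyl in place of isopropyl on an oxygen next to a carbonyl group.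

Compound 3 `CCNC(=O)Nc1sc2ccccc2c1C(=O)N1CCN(C2CCN(C(=O)NC(C)(C)C)CC2)CC1` changes the same part of the molecule: (tert-butyl)amino stands in place of cyclohexyloxy on a carbonyl carbon ((tert-butyl)amino in place of cyclohexyloxy on a carbonyl carbon). Among the compounds with values here, that step from compound 1 is the only guide, and no measured pair shows what swapping the oxygen for a nitrogen does here. A modest move back towards a lower number therefore seems likely, though with little certainty about its direction. The expected change is a 2.1-fold lower number from compound 2 to compound 3 (0.33 log units; beyond the scatter). For compound 3 the estimated value is 300 nM, with an expected range of 80 nM to 1100 nM.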

Compound 3, half-maximal inhibitory concentration: 775 nM
Compound 3: the middle estimate sits 2.6-fold (0.41 log units) below what was measured; low and high end bracket the measured number.
By their numbers in this assay, from the lowest: compound 1; then compounds 2 and 3 (each within the scatter of the next).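

In this assay, replacing cyclohexyloxy with (tert-butyl)amino on a carbonyl carbon gives a 1.2-fold higher number from compound 2 to compound 3 (0.09 log units; within the scatter), so this change of ring for open chain and of linking oxygen for nitrogen leaves compounds 2 and 3 indistinguishable. Replacing the isopropoxy group instead gives a 3.7-fold higher number from compound 1 to compound 3 (0.57 log units; beyond the scatter), which leaves compound 1 the strongest inhibitor of the three, as its steps to both others lie beyond the scatter. Nothing available gives a reason for these results.

It remains open what the swap from oxygen to nitrogen does alone, as no pair shown carries the same group through both atoms; isopropylamino, set against the isopropoxy group of compound 1, would isolate it. Going by these compounds, how a smaller methoxy group would behave on this carbonyl carbon also remains open.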